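Methyl for chloro at the top of the series

The compounds below may be only part of what the source reports. "The series", "measured", "known", "first", "only" and "open" are said of these compounds alone.

Among the compounds with values here, in an in vivo ADME assay on the whole organism (strain BALB/c) for pharmacokinetics, with Mus musculus as the target, read by LC-MS, at a dose of 5 mg/kg by the oral route (a lower number here means that a smaller share of the oral dose reaches the circulation, a higher number that a larger share of the oral dose reaches the circulation), compound 3 `CS(=O)(=O)c1ccc(Cl)c(C#Cc2cc(Cl)ccc2OCC(=O)O)c1` gives 141% as the highest of the three numbers so far. Compound 1 `Cc1ccc(S(=O)(=O)N2CCOCC2)cc1C#Cc1cc(Cl)ccc1OCC(=O)O` gives 48% in the same read-out, and compound 2 `CC(C)c1ccc(S(C)(=O)=O)cc1C#Cc1cc(Cl)ccc1OCC(=O)O` gives 29% there.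

Next comes compound 4 `Cc1ccc(S(C)(=O)=O)cc1C#Cc1cc(Cl)ccc1OCC(=O)O`, with methyl in place of chloro on an aromatic carbon, para to a methylsulfonyl group: methyl in place of chloro on an aromatic carbon marks the change.

Within the data shown here, no measured step has methyl replacing chloro directly. The one that bears on it is a number 112 percentage points higher from compound 2 to compound 3 (beyond the scatter) with chloro in place of isopropyl on the same aromatic carbon. Read in reverse, it points to a fall when chloro leaves. Compound 1 also carries methyl on the matching carbon and reaches 48% in this assay, but it differs from compound 4 in a second place, so it is only a loose guide.

A large fall is therefore expected, a number 81 percentage points lower from compound 3 to compound 4 (beyond the scatter) as the estimated step. For compound 4 the estimated value is 60% with an expected range of 30% to 100% in this read-out.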

Compound 4, oral bioavailability: 49%
The estimate for compound 4 lay 11 percentage points above the measured number; the measured number falls inside the stated range.
By their numbers in this assay, from the lowest: compound 2; then compounds 1 and 4 (each within the scatter of the next); then compound 3.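

On this aromatic carbon, para to a methylsulfonyl group, chloro and methyl can now be compared directly: in this assay, methyl in place of chloro gives a number 92 percentage points lower from compound 3 to compound 4 (beyond the scatter). Methyl in place of isopropyl on the same carbon gives only a number 20 percentage points higher from compound 2 to compound 4 (beyond the scatter), so among the three groups tried here, chloro stands far above both methyl and isopropyl, while methyl stands modestly above isopropyl. With methyl held on that carbon, methyl in place of morpholin-4-yl on the sulfonyl sulfur gives a number 1 percentage points higher from compound 1 to compound 4 (within the scatter), and nothing at hand explains the size of the chloro effect.

Still open, as far as these compounds go, is whether chloro keeps this standing when morpholin-4-yl sits on the sulfonyl sulfur. Also open, from the compounds shown here alone, is how fluoro, methoxy or a nitrile on the same aromatic carbon would rank against chloro.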